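This account rests on a few compounds, and the source may have more. Where it says the series, first, only, none or still open, it means among the compounds named here.

Working notes on the series. In a physicochemical assay for solubility, at pH 6.8 (a lower number here means a less soluble compound, a higher number a more soluble compound), compound 1 `Cc1c(-c2ccccc2)c(N2CC[C@H](N(C)C)C2)n2nc(C(C)(C)C)cc2c1C#N` gives < 2 ug/mL, which is a limit of the assay rather than a number. Compound 2 `Cc1c(-c2ccccc2)c(N2CC[C@H](N(C)C)C2)n2nc(C(C)(C)COCc3ccccc3)nc2c1C#N` gives < 3 ug/mL, likewise a limit. Within the data shown here, compound 3 `Cc1c(-c2ccccc2)c(N2CC[C@H](N(C)C)C2)n2nc(C3CC3)nc2c1C#N` gives 57 ug/mL, the only numerical value among the three; the other two sit at the limit of < 2 ug/mL in this assay, at which 1 of the 3 values shown sits, and at the limit of < 3 ug/mL in this assay, at which 1 of the 3 values shown sits, so compound 3 stands as the one compound with a measured number, and the gap to the others cannot be sized exactly.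

Among the measured compounds shown here, one measured step bears on the position in question: an at least 19-fold higher number from compound 2 to compound 3 (1.27 log units; beyond the scatter). It replaces a bulky group with a small ring on the same aromatic carbon, and its size is large.

Compound 4 `CCc1nc2c(C#N)c(C)c(-c3ccccc3)c(N3CC[C@H](N(C)C)C3)n2n1` differs from compound 3 by ethyl in place of cyclopropyl on an aromatic carbon. Both groups are small carbon substituents, far closer to each other than the pair in the measured step, so no step beyond the scatter is expected in this assay. The expected step is therefore a 1.1-fold lower number from compound 3 to compound 4 (0.06 log units; within the scatter). Compound 4 is expected to give 50 ug/mL, with a range from 18 ug/mL to 140 ug/mL.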

Compound 4, solubility: 228 ug/mL
Beside the measured number, compound 4's estimate is 4.6-fold (0.66 log units) below it; the whole stated range lies below it.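

In this assay, this position responds even to an exchange of two small carbon groups: a 4.0-fold higher number from compound 3 to compound 4 (0.60 log units; beyond the scatter) with ethyl in place of cyclopropyl, so the ring at this carbon cannot be treated as interchangeable with a short open chain. Among these compounds, the step of an at least 76-fold higher number from compound 2 to compound 4 (1.88 log units; beyond the scatter) is wider than any step the earlier compounds could show, although compound 2 gives < 3 ug/mL as a limit of the assay, not a number. No measurement shown here accounts for the difference between ethyl and cyclopropyl.

Open, going by these compounds, is how methyl or a longer chain such as n-propyl would read at this carbon, and so whether ethyl lies at a peak or on a trend. Also open, on these data alone, is how a substituent carrying an amine or a carboxylic acid would read here.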